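The source may hold more compounds than are shown below. What is called first, only, known or untested is meant among the compounds shown, and "the series" means these compounds.

Measured so far:
Compound 1, `CC1=C(C(=O)OCc2ccccc2)C(c2ccco2)NC(=O)N1`, gives 36%.
Compound 2, `CCN(CC)C(=O)C1=C(C)NC(=O)NC1c1ccco1`, gives 11%.

Both compounds were tested in an assay on membranes from CHO cells for displacement of a labelled ligand from adenosine receptor A1 (Homo sapiens), read by scintillation counting, with a stated time of 60 min, tested at 1 uM; a lower number here means less inhibition, a higher number more inhibition at the concentration tested (going by the name of the read-out). Compound 2 stands lowest of the two numbers, and the nearest number, that of compound 1, lies well beyond the usual scatter of repeated measurements. The two compounds share the same core and differ only in the group attached to the carbonyl carbon. Among the measured compounds shown here, no step between measured compounds that differ in a single place is available, so the move to the next compound rests on these two values alone.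

Compound 3, `CCC(C)OC(=O)C1=C(C)NC(=O)NC1c1ccco1`, has not yet been measured in this assay. It differs from compound 2 by sec-butoxy in place of diethylamino on a carbonyl carbon. The group that enters, sec-butoxy, carries one hydrogen-bond acceptor where diethylamino carried none. Compound 1, whose carbonyl also carries an oxygen-linked group, gives 36%. An increase is expected here. The step of a number 17 percentage points higher from compound 2 to compound 3 (beyond the scatter) is expected to be upward and beyond the scatter. In this assay compound 3 is estimated to give 28%, within a range from 10% to 50%.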

Compound 3, a percentage reported as inhibition, at one concentration (the size of the read-out at that concentration, not a potency): 6%
Compound 3: the middle estimate sits 22 percentage points above what was measured; measured number outside the range, below it.
By their numbers in this assay, from the lowest: compounds 3 and 2 (each within the scatter of the next); then compound 1.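

In this assay, sec-butoxy in place of diethylamino on the carbonyl carbon gives a number 5 percentage points lower from compound 2 to compound 3 (within the scatter), so this pair cannot be told apart, and the hydrogen-bond acceptor that sec-butoxy brings makes no readable difference here. An oxygen on the carbonyl is therefore not enough to reach the number of compound 1: with the oxygen kept, sec-butyl in place of benzyl gives a number 30 percentage points lower from compound 1 to compound 3 (beyond the scatter), which points to the group on that oxygen, not the oxygen itself, as what separates these two compounds. Nothing measured alongside these numbers accounts for that difference.

The compounds shown leave open whether another group on the oxygen, such as a longer chain like n-hexyl or a phenethyl group, would read closer to compound 1 or to compound 3. Among the compounds shown here, they also leave open whether a benzylamino group on the same carbonyl carbon would behave like benzyl on the oxygen or like diethylamino, and with only two groups compared on that oxygen, no trend can yet be drawn.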